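The compounds below may be only part of what the source reports. "The series", "measured", "known", "first", "only" and "open" are said of these compounds alone.

Compound 1, `Cc1cc(NC(=O)CC(C)(C)C)nn1Cc1cc(Cl)ccc1OCc1ccccc1`, is the reference point of this pair: in an assay on CHO-K1 cells for displacement of a labelled ligand from prostaglandin E2 receptor EP1 subtype (Homo sapiens) (on this read-out lower numbers stand for stronger inhibition and higher numbers for weaker inhibition), compound 1 gives 10 nM. Compound 2, `Cc1cc(NC(=O)OCC(C)C)nn1Cc1cc(Cl)ccc1OCc1ccccc1`, carries an isobutoxy group on the carbonyl carbon where compound 1 has neopentyl, and in this assay compound 2 gives 25.1 nM. Among the measured compounds shown here, the single measured step, a 2.5-fold higher number from compound 1 to compound 2 (0.40 log units; beyond the scatter), is the only one available, and it leaves compound 2 standing at the higher of the two numbers, with compound 1 as its nearest neighbour.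

Compound 3, `COC(=O)Nc1cc(C)n(Cc2cc(Cl)ccc2OCc2ccccc2)n1`, follows from compound 2 by the change (hydrogen in place of isopropyl on a saturated chain carbon bound to an oxygen next to a carbonyl group), so that the isobutoxycarbonyl group becomes methoxycarbonyl. For the measured compounds named here, no measured step covers this exact move. Going by the values given here, the one step that bears on it at all, a 2.5-fold higher number from compound 1 to compound 2 (0.40 log units; beyond the scatter), shows that trading the larger neopentyl for isobutoxy on the carbonyl carbon weakened binding by a modest amount; shortening the chain further in compound 3 is therefore expected to continue in the same direction rather than reverse it, though with considerable uncertainty since only that one step informs the guess. On that basis the expected step is a 2.0-fold higher number from compound 2 to compound 3 (0.30 log units; within the scatter). Compound 3 is accordingly estimated at 50 nM, with a likely range from 15 nM to 160 nM.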

Compound 3, half-maximal inhibitory concentration: 200 nM
Compound 3: middle estimate off by 4.0-fold (0.60 log units), on the low side; measured number outside the range, above it.
By their numbers in this assay, from the lowest: compound 1; then compound 2; then compound 3.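

In this assay, hydrogen in place of isopropyl on a saturated chain carbon bound to an oxygen next to a carbonyl group gives an 8.0-fold higher number from compound 2 to compound 3 (0.90 log units; beyond the scatter) and so shows that this position is far from indifferent to the loss of the isopropyl, a larger step than the earlier 2.5-fold higher number from compound 1 to compound 2 (0.40 log units; beyond the scatter) on the same carbonyl carbon. Taken from the reference compound, methoxy in place of neopentyl gives a 20-fold higher number from compound 1 to compound 3 (1.30 log units; beyond the scatter) as a large loss, and the three compounds now fall in one order, with neopentyl giving the lowest number, isobutoxy the next and methoxy the highest, none of them going against it. Nothing in the data shown accounts for the size of this step.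

The compounds shown leave open whether ethoxy or a propoxy chain would sit nearer to isobutoxy or to methoxy, and so whether the rise comes gradually or abruptly along this chain. They also leave open whether a longer chain, or an amine on the carbonyl carbon, would bring the number below that of compound 1 or merely match it.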